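Replacing the Chain End of Compound 1 with a Carboxy Group

The source may hold more compounds than are shown below. What is called first, only, known or untested is meant among the compounds shown, and "the series" means these compounds.

Measured compounds:
Compound 1 `N=C(S)CCCn1nc(-c2ccccc2)ccc1=O`: 75.6%
Compound 2 `Cc1ccc(=O)n(CCCCCC(=N)S)n1`: 36.6%
Compound 3 `Cc1ccc(=O)n(CCCC(=N)S)n1`: 36.3%

In a functional assay on the whole organism (stomach) for inhibition, with Rattus norvegicus as the target, at a dose of 100 mg/kg by the intraduodenal route (on this read-out higher numbers stand for more inhibition at the one dose given (going by the name of the read-out) and lower numbers for less inhibition), compound 1 gives 75.6%, the highest of the three numbers, and its steps to both other compounds are beyond the scatter. The change from compound 1 to compound 3 is a number 39.3 percentage points lower from compound 1 to compound 3 (beyond the scatter), a large loss that comes with the methyl in place of phenyl on an aromatic carbon. The change from compound 2 to compound 3 is a number 0.3 percentage points lower from compound 2 to compound 3 (within the scatter), so shortening the chain that carries the sulfur-bearing group made no difference beyond the scatter.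

Compound 4 `O=C(O)CCn1nc(-c2ccccc2)ccc1=O` keeps the phenyl of compound 1 but alters the chain: a group of 3 heavy atoms (1 carbon, 2 oxygen; no ring) in place of a group of 4 heavy atoms (2 carbon, 1 nitrogen, 1 sulfur; no ring), on a saturated chain carbon, two bonds along the chain from an aromatic nitrogen. Within the data shown here, no measured step replaces this chain-end group with a carboxy group, so the comparison of compound 2 with compound 3 is only a loose guide: it shows that the number stayed level when the chain itself was shortened, but not what happens when the group on it is swapped. Since the phenyl, which the step from compound 1 to compound 3 showed to matter greatly, is retained, compound 4 is expected to stay well above compounds 2 and 3, yet with a likely fall from compound 1 of about a number 25.6 percentage points lower from compound 1 to compound 4 (beyond the scatter). Compound 4 is therefore estimated at 50%, within a range from 20% to 80%.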

Compound 4, a percentage reported as inhibition, in the whole organism at one dose (the size of the read-out at that dose, not a potency): 26.1%
For compound 4 the middle estimate is 23.9 percentage points above the measured one; the range from low to high includes it.
By their numbers in this assay, from the lowest: compound 4; then compounds 3 and 2 (each within the scatter of the next); then compound 1.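

In this assay the chain end proves to matter as much as the phenyl: with the phenyl kept, carboxy in place of the original end group gives a number 49.5 percentage points lower from compound 1 to compound 4 (beyond the scatter). The phenyl alone is therefore not enough to hold the inhibition in compound 4. Until now, the only large step came from the change on the aromatic carbon, and the one chain change shown, between compound 2 and compound 3, stayed within the scatter. Nothing measured here explains the loss.

As far as these compounds go, it remains open whether an amine or an amide at the chain end would recover the inhibition, and whether a longer chain carrying the carboxy group would do so. From the compounds shown here alone, the effect of carboxy on the methyl-bearing core of compound 3 is also open.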